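The compounds below may be only part of what the source reports. "The series", "measured", "known", "first", "only" and "open" are said of these compounds alone.

In an assay on isolated protein for binding affinity to fibroblast growth factor 1 (Homo sapiens), read by surface plasmon resonance (a higher number here means weaker binding, a lower number tighter binding), three sulfated sugar derivatives sharing one core have been measured. Compound 1 `CCN(CC(=O)NC[C@H]1O[C@H](OC)[C@@H](OS(=O)(=O)O)[C@@H](OS(=O)(=O)O)[C@@H]1OS(=O)(=O)O)C(=O)CCCCCCCCCOS(=O)(=O)O` gives 111000 nM, compound 2 `CO[C@H]1O[C@H](CNC(=O)CN(CCOS(=O)(=O)O)C(C)=O)[C@@H](OS(=O)(=O)O)[C@H](OS(=O)(=O)O)[C@@H]1OS(=O)(=O)O` gives 95000 nM, and compound 3 `CO[C@H]1O[C@H](CNC(=O)CN(C(C)=O)C2CCCCCC2)[C@@H](OS(=O)(=O)O)[C@H](OS(=O)(=O)O)[C@@H]1OS(=O)(=O)O` gives 370000 nM. Compound 1 thus stands second highest of the three, within the scatter of compound 2 and clearly below compound 3.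

Compound 4 `CCN(CC(=O)NC[C@H]1O[C@H](OC)[C@@H](OS(=O)(=O)O)[C@@H](OS(=O)(=O)O)[C@@H]1OS(=O)(=O)O)C(=O)CCCc1ccccc1` has not yet been measured. It differs from compound 1 in one place: phenyl in place of 6-(sulfooxy)hexyl on a saturated chain carbon, three bonds along the chain from a carbonyl carbon. Within the data shown here, the one measured step that resembles this change is a 3.9-fold higher number from compound 2 to compound 3 (0.59 log units; beyond the scatter), where a chain ending in a sulfooxy group was likewise exchanged for a ring of carbon alone, and the number rose. The change from compound 1 to compound 4 also removes a sulfooxy-bearing chain and brings in a carbon ring, so a step of similar size and direction is expected, a 2.9-fold higher number from compound 1 to compound 4 (0.46 log units; beyond the scatter), toward weaker binding. Compound 4 is therefore estimated at 320000 nM, with a likely range from 120000 nM to 850000 nM.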

Compound 4, dissociation constant: 500000 nM
Compound 4: middle estimate off by 1.6-fold (0.19 log units), on the low side; measured number inside the range.
By their numbers in this assay, from the lowest: compounds 2 and 1 (each within the scatter of the next); then compounds 3 and 4 (each within the scatter of the next).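

In this assay putting phenyl in place of 6-(sulfooxy)hexyl on this saturated chain carbon gives a 4.5-fold higher number from compound 1 to compound 4 (0.65 log units; beyond the scatter) and so weaker binding. Among these compounds, earlier, an exchange of a sulfooxy-bearing chain for a ring of carbon alone had been seen only on an amide-type nitrogen, in a 3.9-fold higher number from compound 2 to compound 3 (0.59 log units; beyond the scatter) as the one example, and the number now rises in the same direction at a second place in the molecule. Nothing measured here accounts for this rise.

The step removes the sulfooxy group and brings in a ring at once, so the compounds shown cannot separate the two changes. A plain hexyl chain, or a chain of the same length ending in a carboxylic acid, would show how much of the step belongs to the sulfooxy group alone.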